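A few compounds are considered here, and "the series" means these few. Any claim that something is new, unique, unknown or untested is made for them only; others in the source may bear on it.

Measured in a functional assay on Caco-2 cells (Homo sapiens) for inhibition, read by sulforhodamine B assay, with a stated time of 72 h; on this read-out higher numbers stand for weaker inhibition and lower numbers for stronger inhibition:
- Compound 1 `CCC(C)NC(=C\C(=O)/C=C/c1ccc(O)c(OC)c1)/C=C/c1ccc(O)c(OC)c1`: > 25000 nM, a limit.
- Compound 2 `C=CCNC(=C\C(=O)/C=C/c1ccc(O)c(OC)c1)/C=C/c1ccc(O)c(OC)c1`: > 25000 nM, a limit.
- Compound 3 `COc1cc(/C=C/C(=O)/C=C(/C=C/c2ccc(O)c(OC)c2)NC2CCCCC2)ccc1O`: 5100 nM.

Compound 3 is the only one of the three with an actual number, 5100 nM. Compound 4 `CCCCNC(=C\C(=O)/C=C/c1ccc(O)c(OC)c1)/C=C/c1ccc(O)c(OC)c1` carries butyl in place of cyclohexyl on an amine nitrogen. Within the data shown here, two measured steps bear on this change, an at least 4.9-fold lower number from compound 1 to compound 3 (0.69 log units; beyond the scatter) and an at least 4.9-fold lower number from compound 2 to compound 3 (0.69 log units; beyond the scatter). Both lie beyond the scatter, and both end at cyclohexyl. Butyl has no ring, like the sec-butyl of compound 1 and the allyl of compound 2, so a move to a higher number is expected in this assay. The expected step is a 4.3-fold higher number from compound 3 to compound 4 (0.63 log units; beyond the scatter). The estimate for compound 4 is 22000 nM, with a range of 9000 nM to 50000 nM.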

Compound 4, half-maximal inhibitory concentration: 23800 nM
Compound 4: middle estimate off by 1.1-fold (0.03 log units), on the low side; the measured number falls inside the stated range.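

In this assay, among these compounds, replacing cyclohexylamino with butylamino gives the change on this nitrogen its first measured size, a 4.7-fold higher number from compound 3 to compound 4 (0.67 log units; beyond the scatter), where the earlier steps gave only floors. The floors an at least 1.0-fold lower number from compound 1 to compound 4 (0.02 log units; that floor lies within the scatter) and an at least 1.0-fold lower number from compound 2 to compound 4 (0.02 log units; that floor lies within the scatter) cannot separate butyl from sec-butyl or allyl. Those two comparisons rest on a limit of the assay: the limit of > 25000 nM in this assay, at which 2 of the 4 values shown sit.

The compounds shown do not tell whether the ring or the carbon count matters more. As far as these compounds go, a hexyl chain, a cyclopentyl ring or a phenyl ring on this nitrogen remains open.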